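The compounds below may be only part of what the source reports. "The series", "measured", "known", "first", "only" and "open" are said of these compounds alone.

In a functional assay on the whole organism with Mus musculus as the target, with stated times of 60 min and 30 min, at a dose of 10 mg/kg by the oral route (on this read-out higher numbers stand for more inhibition at the one dose given (going by the name of the read-out) and lower numbers for less inhibition), compound 1 `CC1(C)[C@H](CNc2ccc(F)cc2C(F)(F)F)[C@H]1c1ccc(S(N)(=O)=O)cc1` gives -9%, while its mirror image, compound 2 `CC1(C)[C@@H](CNc2ccc(F)cc2C(F)(F)F)[C@@H]1c1ccc(S(N)(=O)=O)cc1`, gives 79%. Among the compounds with values here, the single measured step, a number 88 percentage points higher from compound 1 to compound 2 (beyond the scatter), rests on (the fact that compounds 1 and 2 differ only in the configuration as drawn). Compound 2 therefore stands highest of the two numbers. Compound 3 `CC1(C)[C@@H](CNc2ccc(F)cc2OC(F)F)[C@@H]1c1ccc(S(N)(=O)=O)cc1` differs from compound 2 in one way: difluoromethoxy in place of trifluoromethyl on an aromatic carbon. Within the data shown here, no measured step speaks to a change of this kind, since the one step known concerns configuration alone, so the expectation must stay wide. Compound 3 is expected to give 60%, in a range from 20% to 90%. The expected step is a number 19 percentage points lower from compound 2 to compound 3 (beyond the scatter).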

Compound 3, a percentage reported as inhibition, in the whole organism at one dose (the size of the read-out at that dose, not a potency): 51%
For compound 3 the middle estimate is 9 percentage points above the measured one, within the range that was stated.
By their numbers in this assay, from the lowest: compound 1; then compound 3; then compound 2.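

Swapping trifluoromethyl for difluoromethoxy on this aromatic carbon, ortho to a large group, gives a number 28 percentage points lower from compound 2 to compound 3 (beyond the scatter) in this assay, which shows that the group at this position matters as well as the configuration. Inhibition is reduced but not lost, since compound 3 still gives 51%. Nothing at hand explains the size of this step.

Going by these compounds, whether a nitrile, a methoxy or a chlorine at this position would match compound 2 stays open. So does whether the mirror image of compound 3 would lose its inhibition.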